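The source may report more compounds than this note shows. Statements on the series, on what has been measured and on what is new or still open speak of the compounds shown alone.

Series notes, step from compound 2 to compound 4.

Three compounds carry numbers in a functional assay on SK-BR-3 cells (Homo sapiens) for inhibition, read by CellTiter-Glo, with a stated time of 72 h; a lower number here means a stronger inhibitor, a higher number a weaker inhibitor. Compound 1 `CNc1cc(C(N)=O)ccc1-n1nc(C(C)C)c2c(-n3cnc(-c4cnn(C)c4)c3)ccnc21` gives 419 nM. Compound 2 `CC(C)c1nn(-c2ccc(C(N)=O)c(N[C@H]3CC[C@H](O)CC3)c2)c2nccc(-n3cnc(-c4ccncc4)c3)c12` gives 165 nM. Compound 3 `CC(C)c1nn(-c2ccc(C(N)=O)c(N[C@H]3CC[C@H](O)CC3)c2)c2cccc(-c3cnc4ccccc4c3)c12` gives 39 nM. On these three numbers compound 2 stands second highest: its nearest neighbour is compound 1, whose number is higher by a margin beyond the scatter, and its furthest is compound 3, whose number is lower, again beyond the scatter. No two of the measured compounds differ in one place only, so none of these gaps can be assigned to a single structural change.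

Compound 4 `CC(C)c1nn(-c2ccc(C(N)=O)c(N[C@H]3CC[C@H](O)CC3)c2)c2nccc(-c3ccccc3)c12` is not yet measured. It differs from compound 2 in one place: phenyl in place of 4-(pyridin-4-yl)-1H-imidazol-1-yl on an aromatic carbon. Going by the values given here, no measured pair in this set isolates a change of this kind, so the size of the step is not anchored by the data. The expectation is a step toward a higher number, beyond the scatter but not large, with the step from compound 2 to compound 4 estimated at a 2.4-fold higher number from compound 2 to compound 4 (0.38 log units; beyond the scatter). In this assay compound 4 is therefore expected to give about 400 nM, with a range from 120 nM to 1500 nM.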

Compound 4, half-maximal inhibitory concentration: > 10000 nM
Compound 4 was reported as a limit (the forecaster's own chance of this, stated with the estimate: 5%); middle value at least 25-fold (1.39 log units) from the limit.
By their numbers in this assay, from the lowest: compound 3; then compound 2; then compound 1. At a limit, above all of these: compound 4.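

In this assay, replacing 4-(pyridin-4-yl)-1H-imidazol-1-yl with phenyl on the aromatic carbon opposite the ring nitrogen gives an at least 60-fold higher number from compound 2 to compound 4 (1.78 log units; beyond the scatter), a large step and the first in this set that can be assigned to one place. Compound 4 is reported only as a limit of the assay, not as a number, so this step has a lower bound and no measured size: the limit of > 10000 nM in this assay, at which 1 of the 4 values shown sits. The gaps among compound 1, compound 2 and compound 3 could not be assigned to any single change, whereas this pair shows that the group on this carbon has a strong bearing on the read-out, and that phenyl there does not retain the activity of compound 2.

What remains open is which part of the departing group accounts for the step, since this single pair removes the five-membered and the pyridine ring together. A bare 1H-imidazol-1-yl on this carbon would address that question, as would a pyridin-4-yl attached directly to it or a phenyl carrying an aminomethyl group, and each would also give a measured number in place of a limit if it falls within the range of the assay.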